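The source may hold more compounds than are shown below. What is called first, only, known or untested is meant among the compounds shown, and "the series" means these compounds.

Measured compounds:
compound 1 `COc1ccc(C2OC(c3cc(OC)c(OC)c(OC)c3)=NN2C(C)=O)c(OC)c1`, -3.1%;
compound 2 `COc1cc(C(=O)N/N=C/c2ccccc2C(F)(F)F)cc(OC)c1OC`, 35.6%;
compound 3 `COc1cc(C(=O)N/N=C/c2ccccc2F)cc(OC)c1OC`, 76.5%.

In a functional assay on BGC-823 cells (Homo sapiens) for antiproliferative activity, read by MTT assay, tested at 5 uM (a lower number here means a weaker effect, a higher number a stronger effect of the compound at the concentration tested), compound 1 gives -3.1%. Compound 2 gives 35.6%, and compound 3 gives 76.5%. Compound 2 differs from compound 3 only in the aromatic substituent. Compound 3 thus stands highest of the three numbers, with compound 2 nearest and compound 1 furthest from it.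

Among the compounds with values here, the only step between measured compounds that differ in one place is a number 40.9 percentage points higher from compound 2 to compound 3 (beyond the scatter). It shows that a change of the substituent on the aromatic ring attached to the imine carbon can move the number in this assay by a large amount.

Compound 4 `COc1cc(C(=O)N/N=C/c2cc(Cl)cc(Cl)c2)cc(OC)c1OC` is not yet measured. It differs from compound 3 as follows: 3,5-dichlorophenyl in place of 2-fluorophenyl on a carbon with a double bond to nitrogen. Within the data shown here, no measured step involves either a 3,5-dichlorophenyl group or the removal of the fluoro substituent from compound 3, so the one measured step bears only loosely on this change: it tells that the ring substituents matter, not in which direction. The expectation is therefore broad: a move of a number 26.5 percentage points lower from compound 3 to compound 4 (beyond the scatter) is estimated, most likely downward from compound 3. Compound 4 is expected to give 50%, with a range from 15% to 85%.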

Compound 4, a percentage reported as inhibition, at one concentration (the size of the read-out at that concentration, not a potency): 9.2%
Compound 4: middle estimate off by 40.8 percentage points, on the high side; measured number outside the range, below it.
By their numbers in this assay, from the lowest: compound 1; then compound 4; then compound 2; then compound 3.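

In this assay, 3,5-dichlorophenyl in place of 2-fluorophenyl on the carbon with a double bond to nitrogen brings a number 67.3 percentage points lower from compound 3 to compound 4 (beyond the scatter) and thus takes the series from its highest number to one close to the bottom of the order, with only compound 1 lower. The earlier step, a number 40.9 percentage points higher from compound 2 to compound 3 (beyond the scatter), had shown that one substituent exchanged on this ring can move the number a long way, whereas this result shows a similarly large move when both the halogen and the number of halogen atoms differ, even though the computed hydrogen-bond donor and acceptor counts and the net charge of the two groups are the same. Nothing shown here bears on why the number falls so far at this position.

Since chlorine replaces fluorine and the pattern of substitution on the ring changes in the same step, the compounds shown cannot separate the contribution of the halogen from that of its placement. They also leave open how the number would respond to an unsubstituted phenyl, to 2-chlorophenyl, or to a ring carrying a hydroxyl group or an amine at this position.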